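Ethoxy to benzylamino on the core: expected inhibitory concentration

The compounds below may be only part of what the source reports. "The series", "measured", "known", "first", "only" and "open" are said of these compounds alone.

Compound 1 `CCOC1=C(C(=O)c2ccccc2)C(c2ccc(Br)cc2)N(CCCn2ccnc2)C1=O` in a functional assay on NCI-H1299 cells (Homo sapiens) for antiproliferative activity, read by MTT assay, with a stated time of 72 h (on this read-out higher numbers stand for weaker inhibition and lower numbers for stronger inhibition), gives 28900 nM. Compound 2 `Cc1ccc(NC2=C(C(=O)c3ccccc3)C(c3ccc(Br)cc3)N(CCCn3ccnc3)C2=O)cc1` gives 25800 nM; the step of a 1.1-fold lower number from compound 1 to compound 2 (0.05 log units; within the scatter) leaves the two measured numbers within the scatter of each other, so compound 1 stands unresolved from compound 2. Compound 3 `O=C(C1=C(NCc2ccccc2)C(=O)N(CCCn2ccnc2)C1c1ccc(Br)cc1)c1ccccc1` differs from compound 1 by benzylamino in place of ethoxy on a double-bonded ring carbon. Among the compounds with values here, the one comparable step, a larger amino group for ethoxy at the same place, was a 1.1-fold lower number from compound 1 to compound 2 (0.05 log units; within the scatter), so no step beyond the scatter is expected here either: for compound 3 the expected step is a 1.1-fold lower number from compound 1 to compound 3 (0.03 log units; within the scatter). Compound 3 is therefore estimated at 27000 nM, between 10000 nM and 70000 nM.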

Compound 3, half-maximal inhibitory concentration: 25300 nM
Compound 3: middle estimate off by 1.1-fold (0.03 log units), on the high side, and the stated range covers the measured number.
By their numbers in this assay, from the lowest: compounds 3, 2 and 1 (each within the scatter of the next).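

In this assay benzylamino in place of ethoxy gives a 1.1-fold lower number from compound 1 to compound 3 (0.06 log units; within the scatter) and benzyl in place of 4-methylphenyl gives a 1.0-fold lower number from compound 2 to compound 3 (0.01 log units; within the scatter) on the amine nitrogen. Ethoxy, (4-methylphenyl)amino and benzylamino thus stand unresolved at this double-bonded ring carbon, whether the six-membered aromatic ring sits directly on the amine nitrogen or is carried as benzyl. No data here bear on the reason for this. Open, going by these compounds, is whether an unsubstituted amine, or a carboxylic acid on the benzyl ring, would move the number beyond the scatter.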